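This account rests on a few compounds, and the source may have more. Where it says the series, first, only, none or still open, it means among the compounds named here.

Three carbamates on a shared core have been compared in an ADME assay on a cell-free system (plasma, Homo sapiens), read by HPLC, with a stated time of 120 min, at 37 degrees C; a lower number here means that less of the compound is left, a higher number that more of the compound is left. Compound 1 `CC(OC(=O)N1CCN(C(=O)c2nc(Nc3cc(C4CC4)[nH]n3)c3cc(Cl)ccc3n2)C[C@H]1C)OC(=O)C(C)(C)C` gives 49.4%, compound 2 `C[C@@H]1CN(C(=O)c2nc(Nc3cc(C4CC4)[nH]n3)c3cc(Cl)ccc3n2)CCN1C(=O)OCc1ccccc1` gives 86.2%, and compound 3 `CCCCCOC(=O)N1CCN(C(=O)c2nc(Nc3cc(C4CC4)[nH]n3)c3cc(Cl)ccc3n2)C[C@H]1C` gives 74.4%, which places compound 3 second of the three: a number 11.8 percentage points lower from compound 2 to compound 3 (beyond the scatter) and a number 25 percentage points higher from compound 1 to compound 3 (beyond the scatter). Compound 4 `C[C@@H]1CN(C(=O)c2nc(Nc3cc(C4CC4)[nH]n3)c3cc(Cl)ccc3n2)CCN1C(=O)OCOC(=O)C(C)(C)C` differs from compound 3 in one place: ((tert-butyl)carbonyl)oxy in place of butyl on a saturated chain carbon bound to an oxygen next to a carbonyl group. The most telling measured step is a number 25 percentage points higher from compound 1 to compound 3 (beyond the scatter), which took away a ((tert-butyl)carbonyl)oxy group from the same kind of carbon, and a number 36.8 percentage points higher from compound 1 to compound 2 (beyond the scatter) points the same way. Since the change from compound 3 to compound 4 brings such a group back, a modest downward step is expected, a number 24.4 percentage points lower from compound 3 to compound 4 (beyond the scatter). Compound 4 is therefore estimated at 50%, within 30% to 70%.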

Compound 4, percent of the compound remaining: 0%
Compound 4: the middle estimate sits 50 percentage points above what was measured; the whole stated range lies above it.
By their numbers in this assay, from the lowest: compound 4; then compound 1; then compound 3; then compound 2.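

Among these compounds, the ((tert-butyl)carbonyl)oxy group costs far more on an unsubstituted carbon than the earlier compounds suggested, with a number 74.4 percentage points lower from compound 3 to compound 4 (beyond the scatter) and a number 86.2 percentage points lower from compound 2 to compound 4 (beyond the scatter) in this assay. The methyl on the carbon bound to two oxygens therefore matters greatly, since a number 49.4 percentage points lower from compound 1 to compound 4 (beyond the scatter) with hydrogen in its place . No supporting measurement accounts for this. On these data alone, whether an ethyl group on that carbon would leave more of the compound intact remains open, as does the effect of an acetyl group in place of the (tert-butyl)carbonyl. The read-out also leaves open what compound 4 becomes, since it follows only the compound remaining.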